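The compounds below may be only part of what the source reports. "The series", "measured", "known", "first", "only" and "open" are said of these compounds alone.

Measured compounds:

Compound 1, `O=[N+]([O-])c1c[nH]c(-c2nnc(Cc3ccc(F)c4ccccc34)o2)c1`, gives 229000 nM in an ADME assay on Vero cells (Chlorocebus sabaeus) for cytotoxicity, read by MTT assay, with a stated time of 72 h; a higher number here means a weaker inhibitor, a lower number a stronger inhibitor.
Compound 2, `Cn1cc([N+](=O)[O-])cc1-c1nnc(Cc2ccc(F)c3ccccc23)o1`, gives 119000 nM in this assay.
Compound 3, `O=[N+]([O-])c1c[nH]c(-c2nnc(-c3cccs3)o2)c1`, gives 418000 nM in this assay.

Compounds 1 and 2 share one core and differ in a single place: methyl in place of hydrogen on an aromatic nitrogen. This change moves the number by a 1.9-fold lower number from compound 1 to compound 2 (0.28 log units; within the scatter), a step that stays inside the usual scatter of repeated measurements, so the two values cannot be told apart with confidence.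

Compound 3 carries a different core. The difference between the two cores is not broken down here. Its value is the highest of the three, but its gap to compound 1 lies within the scatter, while its gap to compound 2 lies beyond it.

Compound 4, `Cn1cc([N+](=O)[O-])cc1-c1nnc(-c2cccs2)o1`, has not yet been measured. Among the compounds with values here, it is obtained from compound 3 by methyl in place of hydrogen on an aromatic nitrogen, and this is the same change as the one from compound 1 to compound 2, made at the same kind of position on the ring bearing the nitro group.

Within the data shown here, compound 4 is expected to show a step of about a 1.7-fold lower number from compound 3 to compound 4 (0.22 log units; within the scatter), because the only precedent for this change is the step of a 1.9-fold lower number from compound 1 to compound 2 (0.28 log units; within the scatter), which was small. On that basis, compound 4 is estimated to give 250000 nM in this assay, with a likely range from 120000 nM to 500000 nM.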

Compound 4, half-maximal inhibitory concentration: 521000 nM
Compound 4: the middle estimate sits 2.1-fold (0.32 log units) below what was measured, outside the stated range (above it).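

In this assay, methyl in place of hydrogen on the aromatic nitrogen gives a 1.2-fold higher number from compound 3 to compound 4 (0.10 log units; within the scatter), so this pair cannot be told apart with confidence, just as the pair on the other core could not. The two steps also cannot be told apart from each other: the same change on two cores in this assay, a 1.9-fold lower number (0.28 log units; within the scatter) from compound 1 to compound 2 and a 1.2-fold higher number (0.10 log units; within the scatter) from compound 3 to compound 4, 2.4-fold (0.38 log units) apart, within the scatter of two such steps. On the two cores shown, then, the change carries over in one limited sense, as a step that stays inside the usual scatter each time; this does not show that the change has no effect at all, and two pairs cannot show that it would stay this small on a third core.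

The compounds shown leave open what a group other than methyl would do on that same aromatic nitrogen, such as ethyl, a longer chain or a chain ending in a carboxylic acid, as only hydrogen and methyl appear there. They also leave open how the step would look on a core with an amine in place of the nitro group, and whether this change matters in any measurement other than this assay.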